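The compounds below may be only part of what the source reports. "The series", "measured", "known", "first", "only" and "open" are said of these compounds alone.

Measured compounds:
compound 1, `COc1nc(C)c(Nc2nc(Cl)cn([C@H](CO)C3CC3)c2=O)cc1C`: in an assay on frontal cortex for displacement of a labelled ligand from corticotropin-releasing factor receptor 1 (Rattus norvegicus), with a stated time of 2 h (on this read-out higher numbers stand for weaker inhibition and lower numbers for stronger inhibition), compound 1 gives 88 nM
compound 2, `COc1nc(C)c(Nc2nc(Cl)cn([C@H](COC(=O)Nc3cccc(C#N)c3)C3CC3)c2=O)cc1C`: compound 2 gives 1.3 nM
compound 3, `COc1nc(C)c(Nc2nc(Cl)cn([C@H](COc3ccccn3)C3CC3)c2=O)cc1C`: compound 3 gives 1.2 nM

Compound 3 carries the lowest number of the three, but its distance to compound 2 is within the scatter, so no order between these two is claimed. The step from the compound with hydrogen on this oxygen, by contrast, is large (a 73-fold lower number from compound 1 to compound 3 (1.87 log units; beyond the scatter)).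

Compound 4, `COc1nc(C)c(Nc2nc(Cl)cn([C@H](COc3cccnc3)C3CC3)c2=O)cc1C`, is not yet measured. The change from compound 3 is pyridin-3-yl in place of pyridin-2-yl on an oxygen on a saturated carbon. Within the data shown here, no measured step exchanges one pyridinyl for another on this oxygen, so the bearing of the measured steps is indirect. Two steps show that attaching a group to this oxygen in place of hydrogen gives a large drop (a 68-fold lower number from compound 1 to compound 2 (1.83 log units; beyond the scatter); a 73-fold lower number from compound 1 to compound 3 (1.87 log units; beyond the scatter)). One step shows that two quite different groups on this oxygen give numbers within the scatter of each other (a 1.1-fold lower number from compound 2 to compound 3 (0.03 log units; within the scatter)), which suggests that the identity of the group here matters little once it is present. For compound 4 the expectation is therefore no step beyond the scatter, a 1.7-fold higher number from compound 3 to compound 4 (0.22 log units; within the scatter). The estimate for compound 4 is 2 nM, with a range from 0.7 nM to 6 nM.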

Compound 4, half-maximal inhibitory concentration: 6.7 nM
For compound 4 the middle estimate is 3.4-fold (0.53 log units) below the measured one, and the stated range ends below it.
By their numbers in this assay, from the lowest: compounds 3 and 2 (each within the scatter of the next); then compound 4; then compound 1.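

In this assay, the point of attachment of the pyridine ring on this oxygen matters (a 5.6-fold higher number from compound 3 to compound 4 (0.75 log units; beyond the scatter)), although pyridin-2-yl and pyridin-3-yl have the same atoms and the same counts, so group identity cannot be treated as unimportant here once a group is present. Pyridin-3-yl also falls short of (3-cyanophenyl)carbamoyl (a 5.2-fold higher number from compound 2 to compound 4 (0.71 log units; beyond the scatter)), yet it keeps a large gain over hydrogen (a 13-fold lower number from compound 1 to compound 4 (1.12 log units; beyond the scatter)), showing that the size of that gain depends on the group attached. No evidence is available on the cause of the difference between the two pyridinyl groups.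

Open, going by these compounds, is how pyridin-4-yl or plain phenyl on this oxygen would compare with the two pyridinyl groups. Also open, on these data alone, is whether a longer chain carrying pyridin-2-yl would retain the low number of compound 3 (1.2 nM).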